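Working notes: truncating the basic side arm

The source may report more compounds than this note shows. Statements on the series, on what has been measured and on what is new or still open speak of the compounds shown alone.

Compound 2 `c1ccc2c(c1)CN[C@@H](CN(CCCCNC1CCNCC1)[C@H]1CCCc3cccnc31)C2` gives 63.4 nM in a functional assay on cells for antagonist activity at C-X-C chemokine receptor type 4 (Homo sapiens), read by fluorescence and calcium flux, with stated times of 25 min and 90 s (a lower number here means a stronger inhibitor, a higher number a weaker inhibitor), and stands highest of the two numbers measured, since compound 1 `c1cncc(CNCCCCN(C[C@H]2Cc3ccccc3CN2)[C@H]2CCCc3cccnc32)c1` gives 15.3 nM. Within the data shown here, the only measured step, a 4.1-fold higher number from compound 1 to compound 2 (0.62 log units; beyond the scatter), shows that the distal group on that amine matters modestly. Compound 3 `CC(C)(CCN)CN(C[C@H]1Cc2ccccc2CN1)[C@H]1CCCc2cccnc21` carries a group of 6 heavy atoms (5 carbon, 1 nitrogen; no ring) in place of a group of 10 heavy atoms (8 carbon, 2 nitrogen; one six-membered non-aromatic ring with 1 hetero atom), on a saturated chain carbon bound to an amine nitrogen. Among the measured compounds shown here, no measured step covers removal of the ring-bearing arm, so the expectation rests on compound 2 alone and is uncertain; a weakening of roughly the size of a 2.4-fold higher number from compound 2 to compound 3 (0.37 log units; beyond the scatter) is estimated. Compound 3 is expected to give about 150 nM, within 40 nM to 600 nM.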

Compound 3, half-maximal inhibitory concentration: > 33300 nM
Compound 3: no number, only a limit; the forecaster's own chance of this, stated with the estimate: 5%; middle value at least 220-fold (2.34 log units) from the limit.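

Compound 3 gives no number in this assay, only a limit: the limit of > 33300 nM in this assay, at which 1 of the 3 values shown sits.

On a saturated chain carbon bound to an amine nitrogen, the group of 6 heavy atoms brings an at least 520-fold higher number from compound 2 to compound 3 (2.72 log units; beyond the scatter) and an at least 2100-fold higher number from compound 1 to compound 3 (3.33 log units; beyond the scatter), whereas the earlier exchange at the distal amine brought only a 4.1-fold higher number from compound 1 to compound 2 (0.62 log units; beyond the scatter). Inhibition therefore depends far more on keeping the longer ring-bearing arm than the first pair could show.

On these data alone, whether a longer chain ending in a primary amine, with no ring, would restore inhibition remains open. The compounds shown also do not separate the loss of the ring from the shortening of the arm.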